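Replacing hydroxy on a carbonyl carbon in compound 1

A few compounds are considered here, and "the series" means these few. Any claim that something is new, unique, unknown or untested is made for them only; others in the source may bear on it.

Measured compounds:
compound 1 `O=C(O)CCCCC(CCSC(=O)c1ccccc1)SC(=O)c1ccccc1` gives "not active" (no number reported)
compound 2 `O=C(CCCCC(S)CCS)Nc1ccc([N+](=O)[O-])c(C(F)(F)F)c1` gives 3.2%

In a functional assay on NCI-H460 cells (Homo sapiens) for inhibition, read by MTT assay, with a stated time of 24 h, tested at 0.1 ug/mL (on this read-out lower numbers stand for less inhibition of growth and higher numbers for more inhibition of growth at the one concentration tested), compound 1 has no single number, so it offers no numerical starting point for a step. Compound 3 `O=C(CCCCC(CCSC(=O)c1ccccc1)SC(=O)c1ccccc1)Nc1cccc(Cl)c1` arises from compound 1 through the change (3-chlorophenyl)amino in place of hydroxy on a carbonyl carbon on a carbonyl carbon. Within the data shown here, no measured pair shows this change on its own. Compound 2, also an amide at that carbonyl carbon, stands at 3.2% and so suggests little activity for such amides. Only a small rise in this assay is therefore expected, possibly none beyond the scatter. The estimated inhibition for compound 3 is 5% within an expected range of 0% to 20% at the one concentration tested.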

Compound 3, percent growth inhibition at one concentration: 15.6%
Estimate against measurement, compound 3: 10.6 percentage points below; measured number inside the range.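

Among these compounds, compound 1 carries no number in this assay, so no step to compound 3 can be read. The compounds shown leave open what the (3-chlorophenyl)amino group alone contributes to growth inhibition. No evidence here bears on this result.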